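Chlorine to Fluorine on the Pendant Aryl Group

The source may hold more compounds than are shown below. What is called first, only, known or untested is meant among the compounds shown, and "the series" means these compounds.

Measured compounds:
compound 1 `CNC(=O)c1cc(C(=O)N[C@H]2CC[C@H](O)CC2)n([C@@H](C)c2cccc(Cl)c2)n1`, 3.7
compound 2 `CNC(=O)c1cc(C(=O)N[C@H]2CC[C@H](O)CC2)c([C@@H](C)c2ccc(Cl)cc2)o1`, 3.5

In a physicochemical assay for lipophilicity (a higher number here means a more lipophilic compound, a lower number a more polar compound), compound 1 gives 3.7, while compound 2 gives 3.5. These two values lie within the scatter of each other, so neither compound can be called the more polar of the pair. Compound 3 `CNC(=O)c1cc(C(=O)N[C@H]2CC[C@H](O)CC2)c([C@@H](C)c2cccc(F)c2)o1` has not yet been measured. It differs from compound 2 in one place: 3-fluorophenyl in place of 4-chlorophenyl on a saturated chain carbon bound to an aromatic carbon and a saturated chain carbon. Within the data shown here, no measured pair shows this change. Compound 3 is expected to give 3, within a range from 2.6 to 3.4. That expectation amounts to a step of a number 0.50 log units lower from compound 2 to compound 3 (beyond the scatter), a fall somewhat beyond the scatter.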

Compound 3, distribution coefficient: 4.1
Compound 3: the middle estimate sits 1.10 log units below what was measured; measured number outside the range, above it.
By their numbers in this assay, from the lowest: compounds 2 and 1 (each within the scatter of the next); then compound 3.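

Among these compounds, exchanging 4-chlorophenyl for 3-fluorophenyl on a saturated chain carbon bound to an aromatic carbon and a saturated chain carbon gives a number 0.60 log units higher from compound 2 to compound 3 (beyond the scatter) in this assay, so this position can shift the read-out beyond the scatter, which the earlier compounds could not show. The direction is upward, even though the entering group carries fluorine instead of chlorine. Nothing at hand explains this step.

From the compounds shown here alone, the change alters the halogen and the name's ring number together, so which of the two carries the step stays open. Going by these compounds, a 3-chlorophenyl group on this carbon would separate them, and how an amine there would read is also open.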